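From Chlorophenyl to Nitrophenyl on a Shared Core

The source may hold more compounds than are shown below. What is called first, only, known or untested is meant among the compounds shown, and "the series" means these compounds.

Measured compounds:
compound 1 `O=C(COc1ccc(C(=O)/C=C/c2ccccc2Cl)cc1)N[C@H]1CCOC1=O` — 4610 nM
compound 2 `O=C(CNc1ccccc1Cl)N[C@H]1CCOC1=O` — > 64000 nM
compound 3 `C=CCc1ccc(OCCSC(=S)N[C@H]2CCOC2=O)c(OC)c1` — > 64000 nM

Three compounds were tested in a functional assay on PC-3 cells (Homo sapiens) for antiproliferative activity, read by MTT assay, with a stated time of 72 h; on this read-out lower numbers stand for stronger inhibition and higher numbers for weaker inhibition. Compound 1 `O=C(COc1ccc(C(=O)/C=C/c2ccccc2Cl)cc1)N[C@H]1CCOC1=O` gives 4610 nM. Compound 2 `O=C(CNc1ccccc1Cl)N[C@H]1CCOC1=O` reaches only > 64000 nM, which is a limit of the assay and not a number. Compound 3 `C=CCc1ccc(OCCSC(=S)N[C@H]2CCOC2=O)c(OC)c1` likewise stops at > 64000 nM, again a limit rather than a number. Going by the values given here, compound 1 therefore stands as the only compound with a measured number, set against (the limit of > 64000 nM in this assay, at which 2 of the 3 values shown sit). Among the compounds with values here, no pair of measured compounds differs in a single place, so there is no measured step to lean on.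

Compound 4 `O=C(COc1ccc(C(=O)/C=C/c2cccc([N+](=O)[O-])c2)cc1)N[C@H]1CCOC1=O` has not yet been measured. It differs from compound 1 by 3-nitrophenyl in place of 2-chlorophenyl on a double-bonded chain carbon bound to a double-bonded chain carbon. Within the data shown here, with no measured step of this kind for guidance, the change is expected to move the value in this assay only a little, in no clear direction, and not beyond the usual scatter. Compound 4 is estimated at 4000 nM, with a range from 1200 nM to 14000 nM. This estimate implies a 1.2-fold lower number from compound 1 to compound 4 (0.06 log units; within the scatter), a step expected to sit within the scatter of repeated measurements.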

Compound 4, half-maximal inhibitory concentration: 56300 nM
For compound 4 the middle estimate is 14-fold (1.15 log units) below the measured one, and the stated range ends below it.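

Going by these compounds alone, this is the first measured step on the shared core, and it shows that the group at this place matters: in this assay, 3-nitrophenyl in place of 2-chlorophenyl on a double-bonded chain carbon bound to a double-bonded chain carbon gives a 12-fold higher number from compound 1 to compound 4 (1.09 log units; beyond the scatter). The shared core alone therefore does not fix the value of compound 1, since compound 4 keeps that core and still reads far weaker. Compound 4 also ends up not far under the highest figure reported here, which is a limit and not a number: the limit of > 64000 nM in this assay, at which 2 of the 4 values shown sit.

Because 2-chlorophenyl and 3-nitrophenyl differ both in the group on the ring and in the number of its place, this one step cannot separate the loss of the chlorine, the arrival of the nitro group and the change of place. Whether 3-chlorophenyl, 2-nitrophenyl or an aminophenyl group on this chain carbon would stay with compound 1 or fall with compound 4 remains open in the compounds shown.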